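This account rests on a few compounds, and the source may have more. Where it says the series, first, only, none or still open, it means among the compounds named here.

In a functional assay on DU-145 cells (Homo sapiens) for inhibition, read by trypan blue exclusion, with a stated time of 96 h (a lower number here means a stronger inhibitor of growth, a higher number a weaker inhibitor of growth), compound 1 (`Cc1ccc(CS/C(=C/c2ccccc2F)C(=O)c2ccc(Cl)cc2)cc1`) gives 10000 nM, compound 2 (`Cc1ccsc1/C=C(/SCc1ccc(Cl)cc1Cl)C(=O)c1ccc(Cl)cc1`) gives 10000 nM and compound 3 (`Cc1ccc(CS/C(=C/c2ccc(O)c(O)c2O)C(=O)c2ccc(Cl)cc2)cc1`) gives 50000 nM. Compound 3 therefore has the highest number of the set and is the weakest inhibitor of growth among them.

Compound 4 (`Cc1ccc(CS/C(=C/c2sccc2C)C(=O)c2ccc(Cl)cc2)cc1`) changes one group of compound 3: 3-methylthiophen-2-yl in place of 2,3,4-trihydroxyphenyl on a double-bonded chain carbon bound to a double-bonded chain carbon. The change lies on a double-bonded chain carbon bound to a double-bonded chain carbon.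

Within the data shown here, the only measured step at this place is a 5.0-fold higher number from compound 1 to compound 3 (0.70 log units; beyond the scatter), a modest change that came with 2,3,4-trihydroxyphenyl replacing 2-fluorophenyl. Removing 2,3,4-trihydroxyphenyl may therefore bring the number back down. Compound 2 also carries 3-methylthiophen-2-yl and gives 10000 nM, although it differs from compound 4 elsewhere. Among the measured compounds shown here, no measurement yet shows this group on the exact frame of compound 4.

The expected change is a 5.0-fold lower number from compound 3 to compound 4 (0.70 log units; beyond the scatter), a step of similar size towards a lower number in this assay. The estimate for compound 4 is 10000 nM, with an expected range of 3000 nM to 30000 nM.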

Compound 4, concentration for 50% growth inhibition: 10000 nM
The estimate for compound 4 equals the measured number at the digits printed; the measured number falls inside the stated range.
By their numbers in this assay, from the lowest: compounds 1, 2 and 4 (each within the scatter of the next); then compound 3.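

In this assay, 3-methylthiophen-2-yl in place of 2,3,4-trihydroxyphenyl gives a 5.0-fold lower number from compound 3 to compound 4 (0.70 log units; beyond the scatter), so the trihydroxyphenyl group now stands out against two other groups at this place, each on the same frame. Set against 2-fluorophenyl, the same thiophene group gives no change at the digits printed from compound 1 to compound 4 (within the scatter), so a five-membered and a six-membered aromatic ring cannot be told apart here. At the other end of the molecule, 4-methylphenyl in place of 2,4-dichlorophenyl on a saturated chain carbon bound to a sulfur gives no change at the digits printed from compound 2 to compound 4 (within the scatter), so that swap shows no effect either.

The compounds shown leave open whether an amine or a carboxylic acid on the double-bonded chain carbon would bring the number below that of compound 4. No measurement at hand gives a reason for the higher number of compound 3.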